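The source may report more compounds than this note shows. Statements on the series, on what has been measured and on what is new or still open speak of the compounds shown alone.

In a functional assay on A549 cells (Homo sapiens) for antiproliferative activity, read by MTT assay, with a stated time of 48 h (on this read-out higher numbers stand for weaker inhibition and lower numbers for stronger inhibition), three compounds that share one core and differ only in the group on the carbonyl carbon have been measured. Compound 1 `COc1ccc(/C=C/c2cc(OC)cc(OC)c2/C=C/C(=O)c2ccc(Cl)c(Cl)c2)cc1` gives 5.9 ug/mL, compound 2 `COc1ccc(/C=C/c2cc(OC)cc(OC)c2/C=C/C(=O)c2ccc(C(F)(F)F)cc2)cc1` gives 7.8 ug/mL, and compound 3 `COc1ccc(/C=C/c2cc(OC)cc(OC)c2/C=C/C(=O)c2ccc(OC)cc2)cc1` gives 4.5 ug/mL. Compound 3 cannot be separated from the other two, as a 1.3-fold lower number from compound 1 to compound 3 (0.12 log units; within the scatter) and a 1.7-fold lower number from compound 2 to compound 3 (0.24 log units; within the scatter) are both small. The next compound, compound 4 `COc1ccc(/C=C/c2cc(OC)cc(OC)c2/C=C/C(=O)c2ccc(-c3ccccc3)cc2)cc1`, has phenyl in place of methoxy on an aromatic carbon, para to a large group (phenyl in place of methoxy on an aromatic carbon), turning 4-methoxyphenyl into 4-phenylphenyl. The closest evidence comes from the other changes to this group, including a 1.3-fold higher number from compound 1 to compound 2 (0.12 log units; within the scatter), and none of the three measured steps goes beyond the scatter. For the measured compounds named here, none of the measured compounds carries phenyl here, so this evidence is only indirect. No clear shift in either direction is therefore expected, and the estimated change is a 1.3-fold higher number from compound 3 to compound 4 (0.12 log units; within the scatter). In this assay, compound 4 is expected to give about 6 ug/mL, with an estimated range from 3 ug/mL to 12 ug/mL.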

Compound 4, half-maximal inhibitory concentration: 4.6 ug/mL
For compound 4 the middle estimate is 1.3-fold (0.12 log units) above the measured one, and the stated range covers the measured number.
By their numbers in this assay, from the lowest: compounds 3, 4, 1 and 2 (each within the scatter of the next).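

In this assay, swapping methoxy for phenyl adds a whole aromatic ring at this place, taking the group from 2 heavy atoms to 6, yet the result is a 1.0-fold higher number from compound 3 to compound 4 (0.01 log units; within the scatter). The comparisons with the other two groups give a 1.7-fold lower number from compound 2 to compound 4 (0.23 log units; within the scatter) and a 1.3-fold lower number from compound 1 to compound 4 (0.11 log units; within the scatter), so the earlier finding now extends to a much larger group: none of the four compounds can be told apart here. Nothing available explains why this larger group leaves the number within the scatter.

As far as these compounds go, whether an amine, a carboxylic acid or a longer chain at this place would move the number beyond the scatter remains open. The compounds shown also leave open whether changes elsewhere on the shared core would have a larger effect than those on the group at the carbonyl carbon.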